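The source may report more compounds than this note shows. Statements on the series, on what has been measured and on what is new or still open speak of the compounds shown alone.

Compounds bearing the shared core of compound 3 `Cc1c(Cc2ccccc2)c(=O)oc2cc(OCC(CN3CCC(C(N)=O)CC3)Oc3ccccc3F)ccc12` have so far been tested only in an ADME assay on A549 cells (Homo sapiens) for cytotoxicity, read by CellTiter-Glo; a higher number here means that more compound is tolerated, a lower number that less compound is tolerated. In this assay compound 3 gives 79600 nM. Its nearest neighbour by value is compound 1 `Cc1c(Cc2ccccc2)c(=O)oc2cc(OCC(O)CNCc3cccs3)ccc12`, which in this assay gives 87300 nM, a figure within the scatter of that of compound 3. Compound 2 `Cc1c(Cc2ccccc2)c(=O)oc2cc(OCC(O)CNn3ccnn3)ccc12` gives in this assay only a limit, > 100000 nM. Going by the values given here, the single measured step, an at least 1.1-fold higher number from compound 1 to compound 2 (0.05 log units; that floor lies within the scatter), runs against the limit of > 100000 nM in this assay, at which 1 of the 3 values shown sits, and therefore cannot be sized beyond its floor.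

Compound 4 `COc1ccc(OC(COc2ccc3c(C)c(Cc4ccccc4)c(=O)oc3c2)CN2CCC(C(N)=O)CC2)cc1` differs from compound 3 at another site entirely: 4-methoxyphenyl in place of 2-fluorophenyl on an oxygen on a saturated carbon. Among the compounds with values here, no measured step touches this aryl ether, so the only guide is that all numbers obtained with this core cluster at the high end of the tested range. The step from compound 3 to compound 4 is therefore expected to be small, a 1.0-fold higher number from compound 3 to compound 4 (0.00 log units; within the scatter), with no direction favoured beyond the scatter. Compound 4 is estimated to give 80000 nM in this assay, with a range from 40000 nM to 160000 nM, and a fair chance that only a limit is reported.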

Compound 4, half-maximal cytotoxic concentration: 94900 nM
Estimate against measurement, compound 4: 1.2-fold (0.07 log units) below; low and high end bracket the measured number.
By their numbers in this assay, from the lowest: compounds 3, 1 and 4 (each within the scatter of the next). At a limit, above all of these: compound 2.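

Going by these compounds alone, the first measured step at this aryl ether, a 1.2-fold higher number from compound 3 to compound 4 (0.08 log units; within the scatter), shows that in this assay 4-methoxyphenyl can stand in place of 2-fluorophenyl on this oxygen without a shift that leaves the scatter. Within the data shown here, compound 4 gives a number rather than a limit, so this step can be sized in full, which the one earlier step could not. The only limit among the compounds shown remains that of compound 2: the limit of > 100000 nM in this assay, at which 1 of the 4 values shown sits.

Still open, as far as these compounds go, is whether a phenyl carrying an amine or a carboxylic acid on this oxygen would move the number beyond the scatter. Also open is whether the carboxamide-bearing end of the side chain has any bearing on the number, since no step shown changes it alone.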